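A few compounds are considered here, and "the series" means these few. Any claim that something is new, unique, unknown or untested is made for them only; others in the source may bear on it.

Compound 2 `CC(C)CCN(CCC(C)C)c1ccc(C(=O)N2CCc3ccc(OS(N)(=O)=O)cc3C2)cc1` stands highest of the two compounds measured in an assay on HEK293 cells for inhibition of Steryl-sulfatase (Homo sapiens), tested at 0.1 uM (a higher number here means a stronger effect of the compound at the concentration tested, a lower number a weaker effect), where compound 2 gives 47%. Compound 1 `NS(=O)(=O)Oc1ccc2c(c1)CN(C(=O)c1ccc(N3CCN(Cc4ccccc4)CC3)cc1)CC2` comes nearest, and in this assay compound 1 gives 20.8%, a gap beyond the usual scatter. Compound 3 `CCN(Cc1ccncc1)c1ccc(C(=O)N2CCc3ccc(OS(N)(=O)=O)cc3C2)cc1` differs from compound 2 in one place: ethyl((pyridin-4-yl)methyl)amino in place of diisopentylamino on an aromatic carbon. Among the compounds with values here, no single-place step between measured compounds is known, so the size of this change can only be expected. The inhibition of compound 3 is expected to fall, the step of a number 17 percentage points lower from compound 2 to compound 3 (beyond the scatter) lying beyond the scatter. Compound 3 is estimated at 30%, within 12% to 50%.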

Compound 3, a percentage reported as inhibition, at one concentration (the size of the read-out at that concentration, not a potency): 47%
Beside the measured number, compound 3's estimate is 17 percentage points below it; the measured number falls inside the stated range.
By their numbers in this assay, from the lowest: compound 1; then compounds 2 and 3 (each within the scatter of the next).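

In this assay, replacing diisopentylamino with ethyl((pyridin-4-yl)methyl)amino on this aromatic carbon gives no change at the digits printed from compound 2 to compound 3 (within the scatter), the only single-place step shown at this position. The read-out therefore holds when a group with no ring gives way to one carrying a six-membered aromatic ring with one hetero atom. Nothing available bears on why the read-out holds. Still open, as far as these compounds go, is how a carboxylic acid or a morpholine on this aromatic carbon would read. From the compounds shown here alone, it is also open whether the ethyl or the (pyridin-4-yl)methyl arm matters more.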